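Benzoate esters of a dihydro core: nitro for methyl

The compounds below may be only part of what the source reports. "The series", "measured", "known", "first", "only" and "open" are said of these compounds alone.

Compound 1 `CC1=CC[C@H](C(C)C)c2cc(C)c(OC(=O)c3cccc(C)c3)cc21` gives the highest of the three numbers recorded so far. In a functional assay on MCF7 cells (Homo sapiens) for antiproliferative activity, read by sulforhodamine B assay, with a stated time of 48 h, tested at 50 uM (a higher number here means more inhibition at the concentration tested (going by the name of the read-out), a lower number less inhibition), compound 1 gives 54.9%. Compound 3 `CC1=CC[C@H](C(C)C)c2cc(C)c(OC(=O)c3ccc(C(F)(F)F)cc3)cc21` carries a trifluoromethyl group on the ester ring and shares the core of compound 1. In this assay compound 3 gives 40.4%, a number beyond the scatter below that of compound 1. Compound 2 `Cc1cc2c(C(C)C)ccc(C)c2cc1OC(=O)c1ccc(C(F)(F)F)cc1` is the fully aromatic counterpart of compound 3. In this assay compound 2 gives 16.8%, the lowest of the three and far below compound 1.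

Compound 4 `CC1=CC[C@H](C(C)C)c2cc(C)c(OC(=O)c3cccc([N+](=O)[O-])c3)cc21` has not been measured in this assay. It differs from compound 1 in one place: nitro in place of methyl on an aromatic carbon. For the measured compounds named here, no pair of measured compounds shows this change, so no measured step guides it. The expected step from compound 1 to compound 4 is a number 7.9 percentage points lower from compound 1 to compound 4 (within the scatter), a modest loss that may lie within the scatter. For compound 4 the estimate in this assay is 47%, with a range from 27% to 67%.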

Compound 4, a percentage reported as inhibition, at one concentration (the size of the read-out at that concentration, not a potency): 29.3%
Estimate against measurement, compound 4: 17.7 percentage points above; the measured number falls inside the stated range.
By their numbers in this assay, from the lowest: compound 2; then compound 4; then compound 3; then compound 1.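

In this assay, nitro in place of methyl on an aromatic carbon, meta to a large group, gives a number 25.6 percentage points lower from compound 1 to compound 4 (beyond the scatter). This is the only single-place step among the compounds shown, and it is the first direct reading of this position: with the shared core and the ester link held constant, the group on the ester ring alone moves the number beyond the scatter. Nothing measured here explains the loss.

As far as these compounds go, whether another group at this position, such as an amine, a carboxylic acid or a longer chain, would keep or lower the number of compound 1 remains open. Also open, from the compounds shown here alone, is whether 3-methylphenyl to 3-nitrophenyl would cost as much on the fully aromatic counterpart of the core.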